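A Chlorophenyl Extension on a Baseline of Limits

The compounds below may be only part of what the source reports. "The series", "measured", "known", "first", "only" and "open" are said of these compounds alone.

Compound 1 `CN1Cc2ccc(OCc3ccccc3)cc2[C@@H](O)C1` is the starting point of this comparison. In an ADME assay on Vero cells (Chlorocebus sabaeus) for cytotoxicity, read by sulforhodamine B assay, with a stated time of 72 h (on this read-out higher numbers stand for weaker inhibition and lower numbers for stronger inhibition), compound 1 gives > 100000 nM, which is a limit of the assay and not a number. Compound 2 `Cc1ccccc1COc1ccc2c(c1)[C@@H](O)CN(C)C2` differs from it in one place, and in this assay compound 2 gives > 100000 nM, again a limit. Compound 3 `COCCOCOc1ccc2c(c1)[C@@H](O)CN(C)C2` is the third member of the set; in this assay compound 3 gives > 50000 nM, also a limit. The steps among these three, a step that the two limits leave unreadable from compound 1 to compound 2, a step that the two limits leave unreadable from compound 1 to compound 3 and a step that the two limits leave unreadable from compound 2 to compound 3, therefore cannot be sized in either direction; all that the measurements show is the limit of > 100000 nM in this assay, at which 2 of the 3 values shown sit, and (the limit of > 50000 nM in this assay, at which 1 of the 3 values shown sits).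

Compound 4 `CN1Cc2ccc(OCc3ccc(-c4cccc(Cl)c4)cc3)cc2[C@@H](O)C1` has not yet been measured. It arises from compound 1 through the change (3-chlorophenyl in place of hydrogen on an aromatic carbon). Among the measured compounds shown here, none of the measured steps introduces an aryl ring on an aromatic carbon, and none of them has a readable size, so no direction beyond the scatter can be drawn from them for this assay. The expectation that the data support is that compound 4 stays near the same limit, with the step of an at least 1.4-fold lower number from compound 1 to compound 4 (0.15 log units; that floor lies within the scatter) estimated as small and uncertain. For compound 4 the expected value in this assay is 70000 nM, within a range from 15000 nM to 200000 nM.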

Compound 4, half-maximal inhibitory concentration: 25500 nM
Compound 4: the middle estimate sits 2.7-fold (0.44 log units) above what was measured; low and high end bracket the measured number.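

Among the compounds shown here, the 3-chlorophenyl group, placed on an aromatic carbon para to a large group, gives the only step in this set that can be read: in this assay it is an at least 3.9-fold lower number from compound 1 to compound 4 (0.59 log units; beyond the scatter), whereas the steps among the three earlier compounds cannot be read. Compound 4 is also the only one of the four to give a number rather than a limit of the assay, so this position can take a change that registers on this read-out, which the methyl of compound 2, also on an aromatic carbon, did not show. The step is only a floor, and its true size stays unknown, because its starting value is itself a limit of the assay: the limit of > 100000 nM in this assay, at which 2 of the 4 values shown sit.

The compounds shown do not tell whether the step belongs to the chlorine or to the added ring as such, since no plain phenyl, no other chlorophenyl and no pyridine ring stands at this place. Nor do they show what an amine or a carboxylic acid on the added ring would give in this assay.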